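The source may report more compounds than this note shows. Statements on the series, on what has been measured and on what is new or still open speak of the compounds shown alone.

Going by the values given here, compound 3 `CC(C(=O)N1CCN(c2cccc(F)c2)CC1)N1C(=O)CCC1=O` stands highest of the three numbers measured so far in a functional assay on the whole organism (strain Swiss) with Mus musculus as the target, in the maximal electroshock model, with a stated time of 0.25 h, at a dose of 100 mg/kg by the intraperitoneal route; on this read-out lower numbers stand for a weaker effect and higher numbers for a stronger effect at the one dose given: compound 3 gives 75%, while compound 1 `CC(C(=O)N1CCN(c2cccc(Cl)c2)CC1)N1C(=O)CCC1=O` gives 50% and compound 2 `CC(C(=O)N1CCN(c2ccc(Cl)cc2)CC1)N1C(=O)CCC1=O` gives 50%. The two steps that lead to compound 3 were both modest and beyond the scatter: a number 25 percentage points higher from compound 1 to compound 3 (beyond the scatter), and a number 25 percentage points higher from compound 2 to compound 3 (beyond the scatter); by contrast no change at the digits printed from compound 1 to compound 2 (within the scatter).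

Compound 4 `CC(C(=O)N1CCN(c2ccccc2)CC1)N1C(=O)CCC1=O` differs from compound 3 in one place:

hydrogen in place of fluoro on an aromatic carbon

Among the compounds with values here, no measured step removes a halogen altogether, so the bearing of the earlier steps is indirect. They show that a fluoro in place of chloro raised the number by a modest amount, and that moving a chloro between two positions changed nothing beyond the scatter. Taking the fluoro away is expected to give up that modest gain rather than add to it, so the step of a number 25 percentage points lower from compound 3 to compound 4 (beyond the scatter) is expected to be a modest fall. Compound 4 is therefore estimated at 50%, with a range from 25% to 75%.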

Compound 4, a percentage reported as activity, at one dose (the size of the read-out at that dose, not a potency): 50%
Compound 4: middle estimate and measured number agree at the digits printed; the measured number falls inside the stated range.
By their numbers in this assay, from the lowest: compounds 1, 2 and 4 (each within the scatter of the next); then compound 3.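

In this assay, the phenyl compound gives the first direct view of what a halogen at this position contributes: a number 25 percentage points lower from compound 3 to compound 4 (beyond the scatter), so the higher number of compound 3 is lost when hydrogen replaces the fluoro. Replacing chloro with hydrogen behaves differently, with no change at the digits printed from compound 1 to compound 4 (within the scatter) and no change at the digits printed from compound 2 to compound 4 (within the scatter), so among these compounds only 3-fluorophenyl stands apart from phenyl, and the halogens do not act as one class. Nothing available explains why fluoro and chloro differ here.

The compounds shown leave open whether a methoxy, a trifluoromethyl or a nitrile in place of the fluoro would stand with compound 3 or with compound 4. They also leave open whether the gap between compound 3 and compound 4 would persist at other doses or times.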